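A few compounds are considered here, and "the series" means these few. Any claim that something is new, unique, unknown or untested is made for them only; others in the source may bear on it.

Three compounds of this series have been run in an ADME assay for permeability; a higher number here means that the compound crosses the layer faster, a lower number that the compound crosses the layer more slowly. Compound 1 `CNC(=O)c1cc(C(=O)N[C@H]2CC[C@H](O)CC2)n([C@@H](C)c2cccc(Cl)c2)n1` gives 235 nm/s, compound 2 `CNC(=O)c1cc(C(=O)N[C@H]2[C@@H]3COC[C@@H]32)c([C@@H](C)c2ccccc2)o1` gives 200 nm/s, and compound 3 `CNC(=O)c1cc(C(=O)NC2CCOCC2)n([C@@H](C)c2ccccc2)n1` gives 270 nm/s. On these numbers compound 3 stands alongside compound 1 and compound 2: the three values lie within the usual scatter of one another, so none of them can be set apart from the rest.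

Compound 4 `CNC(=O)c1cc(C(=O)N[C@H]2[C@@H]3C[C@@H](O)C[C@@H]32)n([C@@H](C)c2ccccc2)n1` has not yet been run. It is compound 3 with one change on the amide-type nitrogen: a group of 7 heavy atoms (6 carbon, 1 oxygen; one three-membered non-aromatic ring of carbon only, one five-membered non-aromatic ring of carbon only) in place of a group of 6 heavy atoms (5 carbon, 1 oxygen; one six-membered non-aromatic ring with 1 hetero atom), on an amide-type nitrogen. Within the data shown here, no step between two measured compounds matches this change, so its direction has to be guessed from the three values at hand. A group of seven heavy atoms with one hydrogen-bond donor replaces a group of six heavy atoms with none, and the expected outcome is a small step downward in this assay, most likely within the scatter. Compound 4 is accordingly estimated at 180 nm/s, with a range from 100 nm/s to 300 nm/s, which means an expected step of a 1.5-fold lower number from compound 3 to compound 4 (0.18 log units; within the scatter).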

Compound 4, apparent permeability: 61 nm/s
Beside the measured number, compound 4's estimate is 3.0-fold (0.47 log units) above it; the measured number lies below the stated range.
By their numbers in this assay, from the lowest: compound 4; then compounds 2, 1 and 3 (each within the scatter of the next).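

Among these compounds, the change on the amide-type nitrogen gives the first step that can be told apart from the scatter: in this assay, replacing oxan-4-yl with the group of a three-membered and a five-membered carbon ring brings a 4.4-fold lower number from compound 3 to compound 4 (0.65 log units; beyond the scatter). Among the compounds shown here, the earlier compounds differed in more than one place and their values could not be set apart, so this single change is the first sign that the group at this position can move the read-out on its own. Nothing at hand explains the size of this step.

The new group differs from oxan-4-yl in its rings and in its hydrogen-bond donor at once, so the compounds shown do not separate these two differences. Going by these compounds, it also remains open how the read-out would respond if a methoxy group stood in place of the hydroxyl on the same carbon rings.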